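Methyl in place of fluoro: compound 3 to compound 4

A few compounds are considered here, and "the series" means these few. Any claim that something is new, unique, unknown or untested is made for them only; others in the source may bear on it.

Three compounds share one core and differ in a single group on the aromatic ring: compound 1 `COc1ccccc1-c1nc2c(N3CCN(C)CC3)nc(C)nc2n1C1CCOCC1`, compound 2 `Cc1nc(N2CCN(C)CC2)c2nc(-c3ccccc3C#N)n(C3CCOCC3)c2n1` and compound 3 `Cc1nc(N2CCN(C)CC2)c2nc(-c3ccccc3F)n(C3CCOCC3)c2n1`. In an ADME assay (liver) for metabolic stability, with Liver microsome (Rattus norvegicus) as the target, read by LC-MS, using microsomes, with a stated time of 30 min, tested at 4 uM (a higher number here means that more of the compound is left, a lower number that less of the compound is left), compound 1 gives 35%, compound 2 gives 21% and compound 3 gives 30%. Compound 3 lies within the scatter of both other compounds.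

Compound 4 `Cc1nc(N2CCN(C)CC2)c2nc(-c3ccccc3C)n(C3CCOCC3)c2n1` carries methyl in place of fluoro on an aromatic carbon, ortho to a large group (methyl in place of fluoro on an aromatic carbon). Three measured exchanges bear on this change. Fluoro in place of methoxy gives a number 5 percentage points lower from compound 1 to compound 3 (within the scatter), and fluoro in place of cyano gives a number 9 percentage points higher from compound 2 to compound 3 (within the scatter). Only cyano in place of methoxy, a number 14 percentage points lower from compound 1 to compound 2 (beyond the scatter), leaves the scatter, and that step is modest. For the measured compounds named here, no measured step exchanges fluoro for methyl, so the data support no direction, and no step beyond the scatter is expected.

The expected step is a number 2 percentage points lower from compound 3 to compound 4 (within the scatter). In this assay the expected value for compound 4 is 28%, with an estimated range from 15% to 42%.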

Compound 4, percent of the compound remaining: 39%
Beside the measured number, compound 4's estimate is 11 percentage points below it; measured number inside the range.
By their numbers in this assay, from the lowest: compounds 2, 3, 1 and 4 (each within the scatter of the next, the first and the last beyond it).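

With methyl, a second group now stands beyond the scatter of cyano at this position, a number 18 percentage points higher from compound 2 to compound 4 (beyond the scatter), in this assay, though the step is modest and methoxy had already shown such a separation. Methyl cannot be told apart from fluoro, a number 9 percentage points higher from compound 3 to compound 4 (within the scatter), or from methoxy, a number 4 percentage points higher from compound 1 to compound 4 (within the scatter), so the four groups do not fall into a firm order, and only cyano stands apart from any of the others, while fluoro lies within the scatter of all three. Nothing available explains these differences.

Still open, as far as these compounds go, is whether an amine, a carboxylic acid or a longer chain on this aromatic carbon would give a larger step than any seen so far. The compounds shown also leave open whether the separation of methyl from cyano would hold on a different core.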